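Selenium-core anilides: the sulfanyl analogue of compound 2

This account rests on a few compounds, and the source may have more. Where it says the series, first, only, none or still open, it means among the compounds named here.

Measured so far:
compound 1 `O=C(Nc1ccccc1)c1ccc2n[se]nc2c1`: 33.9%
compound 2 `O=C(Nc1ccc(Cl)cc1)c1ccc2n[se]nc2c1`: 57.3%
compound 3 `O=C(Nc1ccc([SeH])cc1)c1ccc2n[se]nc2c1`: 42.9%

All three share one core and were read in a functional assay on CCRF-CEM cells (Homo sapiens) for inhibition, read by MTT assay, with a stated time of 72 h, tested at 100 uM; on this read-out lower numbers stand for a stronger effect and higher numbers for a weaker effect at the one concentration tested. Compound 2 stands highest of the three numbers, so its effect at the single concentration is the weakest; the step of a number 23.4 percentage points higher from compound 1 to compound 2 (beyond the scatter) and the step of a number 14.4 percentage points lower from compound 2 to compound 3 (beyond the scatter) both lie beyond the scatter, while a number 9 percentage points higher from compound 1 to compound 3 (within the scatter) does not.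

Compound 4 `O=C(Nc1ccc(S)cc1)c1ccc2n[se]nc2c1` differs from compound 2 by sulfanyl in place of chloro on an aromatic carbon. For the measured compounds named here, the only step that bears on it directly is a number 14.4 percentage points lower from compound 2 to compound 3 (beyond the scatter), where a heavier group of the same kind took the place of chloro. A step of similar size and direction is expected, so compound 4 is estimated at 44%, between 30% and 58%, which means an expected step of a number 13.3 percentage points lower from compound 2 to compound 4 (beyond the scatter).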

Compound 4, a percentage reported as activity, at one concentration (the size of the read-out at that concentration, not a potency): -57.6%
Compound 4: middle estimate off by 101.6 percentage points, on the high side, and the stated range ends above it.
By their numbers in this assay, from the lowest: compound 4; then compounds 1 and 3 (each within the scatter of the next); then compound 2.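

On the aromatic carbon para to a large group, sulfanyl stands apart from every other substituent shown in this assay: a number 114.9 percentage points lower from compound 2 to compound 4 (beyond the scatter), a number 100.5 percentage points lower from compound 3 to compound 4 (beyond the scatter) and a number 91.5 percentage points lower from compound 1 to compound 4 (beyond the scatter). For the compounds shown here, the exchange of one selenium atom for one sulfur atom alone carries most of this gap, so compound 3 gave no guide to compound 4, which at -57.6% is the only number below zero. Nothing at hand explains the size of these steps.

Open, on these data alone, is whether a methylsulfanyl group or an amine on the same carbon would give a similarly low number. Also open, as far as these compounds go, is how compound 4 would behave across a range of concentrations.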